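The source may hold more compounds than are shown below. What is called first, only, known or untested is meant among the compounds shown, and "the series" means these compounds.

Measured compounds:
compound 1 `Cc1cc(C2CCC2)c(S(C)(=O)=O)cc1C(=O)N=C(N)N` – 8.2 nM
compound 2 `Cc1cc(-c2cc(C(F)(F)F)cc(C(F)(F)F)c2)c(S(C)(=O)=O)cc1C(=O)N=C(N)N` – 2800 nM

In a functional assay for inhibition of sodium/hydrogen exchanger (Oryctolagus cuniculus) (a lower number here means a stronger inhibitor, a higher number a weaker inhibitor), compound 1 gives 8.2 nM, the lowest of the two numbers. Compound 2 gives 2800 nM, a higher number beyond the scatter. Compound 3 `Cc1cc(Sc2ccccc2Cl)c(S(C)(=O)=O)cc1C(=O)N=C(N)N` is not yet measured in this assay. It differs from compound 1 by (2-chlorophenyl)sulfanyl in place of cyclobutyl on an aromatic carbon. Compound 2 shows that a larger aromatic group at this position gives a higher number than compound 1; a step upward is therefore expected for compound 3, of moderate size, an 18-fold higher number from compound 1 to compound 3 (1.26 log units; beyond the scatter). Compound 3 is estimated at 150 nM, with a range from 30 nM to 800 nM.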

Compound 3, half-maximal inhibitory concentration: 14 nM
For compound 3 the middle estimate is 11-fold (1.03 log units) above the measured one; the whole stated range lies above it.
By their numbers in this assay, from the lowest: compounds 1 and 3 (each within the scatter of the next); then compound 2.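

In this assay, (2-chlorophenyl)sulfanyl in place of cyclobutyl gives a 1.7-fold higher number from compound 1 to compound 3 (0.23 log units; within the scatter), so this position, ortho to a methylsulfonyl group, can carry a six-membered aromatic ring without leaving the scatter. An aromatic ring here therefore does not by itself go with the high number of compound 2 at 2800 nM, since compound 3 at 14 nM also carries one. No measurement bears on why these two aromatic groups read so differently.

Open, from the compounds shown here alone, is what the sulfur link and the chlorine each contribute, which a phenylsulfanyl group or a 2-chlorophenoxy group would separate. Also open, going by these compounds, is how an amine at this position would read.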